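The compounds below may be only part of what the source reports. "The series", "measured", "known", "first", "only" and "open" are said of these compounds alone.

- compound 1 `CN1C/C(=C\c2cccnc2)C(=O)/C(=C/c2cc([N+](=O)[O-])ccc2F)C1`: 6630 nM
- compound 2 `CN1C/C(=C\c2ccncc2)C(=O)/C(=C/c2ccccc2F)C1`: 4600 nM

Both compounds were tested in a functional assay on HepG2 cells (Homo sapiens) for cytotoxicity, read by MTT assay, with a stated time of 24 h; a lower number here means a stronger inhibitor, a higher number a weaker inhibitor. On these numbers, compound 2 at 4600 nM lies within the scatter of compound 1 at 6630 nM, so the two cannot be ranked.

Compound 3 `CN1C/C(=C\c2ccncc2)C(=O)/C(=C/c2cc([N+](=O)[O-])ccc2F)C1` differs from compound 2 in one place: nitro in place of hydrogen on an aromatic carbon. This puts nitro in place of hydrogen on an aromatic carbon, para to a fluoro group and meta to a large group. No measured pair isolates this change, so its size in this assay is not shown directly. For the measured compounds named here, the only guide is compound 1, which also carries a nitro group and gives 6630 nM. With so little to go on, no step beyond the scatter is expected, and no firm direction can be assigned, although a slightly higher number seems the likelier outcome. The expected change is a 1.2-fold higher number from compound 2 to compound 3 (0.08 log units; within the scatter). In this assay, the estimated value for compound 3 is 5500 nM, with an expected range from 2300 nM to 13000 nM.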

Compound 3, half-maximal inhibitory concentration: 5200 nM
For compound 3 the middle estimate is 1.1-fold (0.02 log units) above the measured one, and the stated range covers the measured number.
By their numbers in this assay, from the lowest: compounds 2, 3 and 1 (each within the scatter of the next).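

In this assay, for the compounds shown here, the step of a 1.1-fold higher number from compound 2 to compound 3 (0.05 log units; within the scatter) gives the first direct reading of nitro in place of hydrogen on this aromatic carbon, para to a fluoro group and meta to a large group, and it lies within the scatter. The second pair, with the nitro group present in both compounds, gives a 1.3-fold lower number from compound 1 to compound 3 (0.11 log units; within the scatter) for pyridin-4-yl in place of pyridin-3-yl on the double-bonded chain carbon, and this step also lies within the scatter, so neither change separates the compounds in this cytotoxicity read-out. Nothing measured here bears on why these steps are so small.

The compounds shown leave open whether an amine or a carboxylic acid on the same aromatic carbon would give a step beyond the scatter, since the only comparison at this position is between nitro and hydrogen. They also leave open whether the exchange between pyridin-4-yl and pyridin-3-yl would read the same with hydrogen in place of the nitro group.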